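This account rests on a few compounds, and the source may have more. Where it says the series, first, only, none or still open, it means among the compounds named here.

In a physicochemical assay for lipophilicity, at pH 7.4 (a higher number here means a more lipophilic compound, a lower number a more polar compound), three compounds sharing one core have been measured. Compound 1 `CCc1ccc(N(CC(C)C)S(=O)(=O)c2ccc3c(c2)C(O)CC(C2CCOCC2)O3)cc1` gives 4.12, compound 2 `CC(C)CN(c1cc2ccccc2s1)S(=O)(=O)c1ccc2c(c1)C(O)CC(C1CCOCC1)O2` gives 3.92, and compound 3 `CC(C)CN(c1ccc(N(C)C)cc1)S(=O)(=O)c1ccc2c(c1)C(O)CC(C1CCOCC1)O2` gives 3.51, the lowest of the three. Compound 4 `CC(C)CN(c1ccccc1C(F)(F)F)S(=O)(=O)c1ccc2c(c1)C(O)CC(C1CCOCC1)O2` carries 2-(trifluoromethyl)phenyl in place of 4-(dimethylamino)phenyl on a sulfonamide nitrogen. Going by the values given here, two measured steps bear on this change, since both bring in the dimethylamino group: a number 0.61 log units lower from compound 1 to compound 3 (beyond the scatter) and a number 0.41 log units lower from compound 2 to compound 3 (beyond the scatter). Both are modest falls, so removing that group is expected to give a modest rise. Among the compounds with values here, no measured compound carries trifluoromethyl, which leaves the size uncertain. The expected change is a number 0.49 log units higher from compound 3 to compound 4 (beyond the scatter). For compound 4 the estimate is 4, with an expected range from 3.6 to 4.4.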

Compound 4, distribution coefficient: 4.14
Compound 4: middle estimate off by 0.14 log units, on the low side; the measured number falls inside the stated range.
By their numbers in this assay, from the lowest: compound 3; then compounds 2, 1 and 4 (each within the scatter of the next).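

In this assay, 2-(trifluoromethyl)phenyl on the sulfonamide nitrogen gives a number 0.63 log units higher from compound 3 to compound 4 (beyond the scatter). The other two steps, a number 0.22 log units higher from compound 2 to compound 4 (within the scatter) and a number 0.02 log units higher from compound 1 to compound 4 (within the scatter), show no real separation, so among these four groups only 4-(dimethylamino)phenyl stands apart. Nothing shown here gives a cause for these steps.

Going by these compounds, it remains open whether 4-(trifluoromethyl)phenyl would behave like 2-(trifluoromethyl)phenyl at this place. On these data alone, it is also open whether a phenyl carrying a carboxylic acid or a primary amine would sit as low as compound 3.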